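Azocane in place of methyl(phenyl)amino on the shared core

A few compounds are considered here, and "the series" means these few. Any claim that something is new, unique, unknown or untested is made for them only; others in the source may bear on it.

Measured so far in a functional assay on CHO-K1 cells for antagonist activity at transient receptor potential cation channel subfamily V member 1 (Homo sapiens), read by FLIPR; a higher number here means a weaker inhibitor, a lower number a stronger inhibitor:
compound 1 `CC(C(=O)NCc1ccc(C(F)(F)F)nc1N(C)c1ccccc1)c1ccc(NS(C)(=O)=O)c(F)c1` gives 0.9 nM
compound 2 `Cc1ccc(CC2CCN(c3nc(C(F)(F)F)ccc3CNC(=O)C(C)c3ccc(NS(C)(=O)=O)c(F)c3)CC2)cc1` gives 0.2 nM
compound 3 `CC(C(=O)NCc1ccc(C(F)(F)F)nc1N1CCC2(CC1)CC(c1ccccc1)=NO2)c1ccc(NS(C)(=O)=O)c(F)c1` gives 6.1 nM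

Compound 1 stands second highest of the three numbers in this assay; compound 2 sits lower, beyond the scatter, and compound 3 sits higher, also beyond the scatter. Both neighbours carry a saturated nitrogen ring at the position in question, and the two results bracket compound 1 from either side.

Compound 4 `CC(C(=O)NCc1ccc(C(F)(F)F)nc1N1CCCCCCC1)c1ccc(NS(C)(=O)=O)c(F)c1` has not been measured. The change from compound 1 is a group of 8 heavy atoms (7 carbon, 1 nitrogen; one eight-membered non-aromatic ring with 1 hetero atom) in place of a group of 8 heavy atoms (7 carbon, 1 nitrogen; one six-membered aromatic ring of carbon only), on an aromatic carbon. For the measured compounds named here, no pair of measured compounds differs at this one place alone, so the step has to be judged from where compound 1, compound 2 and compound 3 stand. Compound 2 with its saturated ring gives 0.2 nM, compound 3 gives 6.1 nM; a saturated ring of eight members on this carbon is expected to land between them, close to compound 1. The expected step of a 2.2-fold higher number from compound 1 to compound 4 (0.35 log units; beyond the scatter) is small, slightly toward a higher number, and may fall within the scatter.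

For compound 4 the estimate in this assay is 2 nM, with a range from 0.4 nM to 10 nM.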

Compound 4, inhibition constant: 0.7 nM
Beside the measured number, compound 4's estimate is 2.9-fold (0.46 log units) above it; the measured number falls inside the stated range.
By their numbers in this assay, from the lowest: compound 2; then compounds 4 and 1 (each within the scatter of the next); then compound 3.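

For the compounds shown here, this is the first step read at this place alone: in this assay, the eight-membered non-aromatic ring in place of methyl(phenyl)amino gives a 1.3-fold lower number from compound 1 to compound 4 (0.11 log units; within the scatter). On the shared core, the six-membered aromatic ring of carbon only is therefore not needed at this aromatic carbon for a result level with compound 1, and the two groups, which match in heavy atoms and hydrogen-bond counts, cannot be told apart here. Nothing at hand bears on why they read alike.

The compounds shown leave open how small the group on this carbon can be, which a dimethylamino group or a pyrrolidine ring would test. They also leave open whether a ring oxygen, as in morpholine, would read the same in this assay.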